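A few compounds are considered here, and "the series" means these few. Any claim that something is new, unique, unknown or untested is made for them only; others in the source may bear on it.

Values in an ADME assay on the whole organism (plasma, Homo sapiens) for pharmacokinetics, read by LC-MS, at a dose of 60 mg by the oral route; on this read-out lower numbers stand for lower exposure and higher numbers for higher exposure at the dose given:
- compound 1 `CN(C)C(=O)[C@H]1CC[C@H](NC(=O)C(=O)Nc2ccc(Cl)cn2)[C@H](NC(=O)c2nc3c(s2)CNCC3)C1` gives 56.2 ng.h/mL
- compound 2 `CN1CCc2nc(C(=O)N[C@@H]3C[C@@H](C(=O)N(C)C)CC[C@@H]3NC(=O)C(=O)O)sc2C1` gives 95.8 ng.h/mL
- compound 3 `CN1CCc2nc(C(=O)N[C@@H]3C[C@@H](C(=O)O)CC[C@@H]3NC(=O)C(=O)Nc3ccc(Cl)cn3)sc2C1` gives 147 ng.h/mL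

Compound 3 holds the highest of these three numbers, yet compound 2 lies within the scatter of it, and only compound 1 lies beyond the scatter. Compound 4 `CNC(=O)[C@H]1CC[C@H](NC(=O)C(=O)Nc2ccc(Cl)cn2)[C@H](NC(=O)c2nc3c(s2)CN(C)CC3)C1` has methylamino in place of hydroxy on a carbonyl carbon, which turns carboxy to methylcarbamoyl (methylamino in place of hydroxy on a carbonyl carbon). Among the measured compounds shown here, no step between measured compounds isolates this kind of change. The measured values run only from compound 1 at 56.2 ng.h/mL to compound 3 at 147 ng.h/mL, so a small fall in this assay is expected, probably none beyond the scatter. The expected change is a 1.8-fold lower number from compound 3 to compound 4 (0.26 log units; within the scatter). For compound 4 the estimated value is 80 ng.h/mL, within a range of 30 ng.h/mL to 170 ng.h/mL.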

Compound 4, area under the concentration-time curve: 4.41 ng.h/mL
For compound 4 the middle estimate is 18-fold (1.26 log units) above the measured one; measured number below the stated range.
By their numbers in this assay, from the lowest: compound 4; then compounds 1, 2 and 3 (each within the scatter of the next, the first and the last beyond it).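

In this assay, methylamino in place of hydroxy on a carbonyl carbon gives a 33-fold lower number from compound 3 to compound 4 (1.52 log units; beyond the scatter), a large step and the first measured at this place. Exposure therefore depends strongly on this position, even though the computed count of hydrogen-bond donors stays the same and neither group carries a net charge. No measurement shown here explains the drop.

On these data alone, whether a plain amino group or an ethylamino group on this carbonyl carbon would also give such low exposure remains open. So does whether the same change would have a similar effect on a different core.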